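The source may hold more compounds than are shown below. What is called first, only, known or untested is meant among the compounds shown, and "the series" means these compounds.

Measured compounds:
Compound 1 `COc1ccc(Cn2cc(CNC(=O)c3cn(-c4ccccc4)nc3-c3ccccc3)nn2)cc1`: > 100000 nM
Compound 2 `O=C(NCc1cn(Cc2ccc(C(F)(F)F)cc2)nn1)c1cn(-c2ccccc2)nc1-c1ccc(F)cc1`: 810 nM
Compound 3 `COc1ccc(Cn2cc(CNC(=O)c3cn(-c4ccccc4)nc3-c3ccc(F)cc3)nn2)cc1`: 650 nM

In a functional assay on MCF7 cells (Homo sapiens) for antiproliferative activity, read by sulforhodamine B assay, with a stated time of 48 h (a higher number here means a weaker inhibitor of growth, a lower number a stronger inhibitor of growth), compound 3 gives 650 nM, the lower of the two numbers reported. Compound 2 gives 810 nM, and the step of a 1.2-fold lower number from compound 2 to compound 3 (0.10 log units; within the scatter) lies within the scatter. For compound 1 the value is a limit of the assay (the limit of > 100000 nM in this assay, at which 1 of the 3 values shown sits). The step of an at least 150-fold lower number from compound 1 to compound 3 (2.18 log units; beyond the scatter) is large.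

Compound 4 `COc1cc(Cn2cc(CNC(=O)c3cn(-c4ccccc4)nc3-c3ccc(F)cc3)nn2)cc(OC)c1OC` differs from compound 3 by 3,4,5-trimethoxyphenyl in place of 4-methoxyphenyl on a saturated chain carbon bound to an aromatic nitrogen. Among the compounds with values here, only one measured step touches that place: the change from compound 2 to compound 3 at the same position gave a 1.2-fold lower number from compound 2 to compound 3 (0.10 log units; within the scatter), within the scatter. No step beyond the scatter is therefore expected in this assay for compound 4, which is estimated at 600 nM, between 200 nM and 2000 nM, a step of a 1.1-fold lower number from compound 3 to compound 4 (0.03 log units; within the scatter).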

Compound 4, concentration for 50% growth inhibition: 4300 nM
The estimate for compound 4 lay 7.2-fold (0.86 log units) below the measured number, outside the stated range (above it).
By their numbers in this assay, from the lowest: compounds 3 and 2 (each within the scatter of the next); then compound 4. At a limit, above all of these: compound 1.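

In this assay, the place on a saturated chain carbon bound to an aromatic nitrogen proves sensitive to the group it carries: 3,4,5-trimethoxyphenyl gives a 6.6-fold higher number from compound 3 to compound 4 (0.82 log units; beyond the scatter) and a 5.3-fold higher number from compound 2 to compound 4 (0.72 log units; beyond the scatter), whereas 4-methoxyphenyl and 4-(trifluoromethyl)phenyl stood within the scatter of each other. The earlier exchange therefore did not show the full range of this place. Nothing measured here accounts for the step.

Going by these compounds, whether all the added methoxy groups are needed for this step remains open, as does how an amine or a carboxylic acid on this aromatic ring would read.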